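Removing the hydroxy from the side chain of a bisphenol

The compounds below may be only part of what the source reports. "The series", "measured", "known", "first", "only" and "open" are said of these compounds alone.

Three compounds of the shared core of compound 1 `COc1cc(C(c2ccc(O)c(OC)c2)[C@H](C)[C@H](C)CF)ccc1O` have been measured in a functional assay on HeLa cells (Homo sapiens) for cytotoxicity, read by WST assay, with a stated time of 48 h; a lower number here means a stronger inhibitor, a higher number a weaker inhibitor. Compound 1 gives 75000 nM. Compound 2 `COc1cc(C(c2ccc(O)c(OC)c2)[C@H](CO)C(C)C)ccc1O` stands only at a limit of the assay, > 100000 nM, and not at a number; (the limit of > 100000 nM in this assay, at which 1 of the 3 values shown sits). Compound 3 `CCCCCCCC[C@H](C(C)C)C(c1ccc(O)c(OC)c1)c1ccc(O)c(OC)c1` gives 3100 nM. The step of an at least 1.3-fold higher number from compound 1 to compound 2 (0.12 log units; that floor lies within the scatter) came with 1-(hydroxymethyl)-2-methylpropyl in place of 2-(fluoromethyl)-1-methylpropyl on a saturated chain carbon bound to two aromatic carbons, while the step of an at least 32-fold lower number from compound 2 to compound 3 (1.50 log units; beyond the scatter) came with heptyl in place of hydroxy on a saturated chain carbon, three bonds along the chain from two aromatic carbons.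

Compound 4 `COc1cc(C(c2ccc(O)c(OC)c2)[C@@H](C)C(C)C)ccc1O` is not yet measured. It differs from compound 2 by 1,2-dimethylpropyl in place of 1-(hydroxymethyl)-2-methylpropyl on a saturated chain carbon bound to two aromatic carbons. Among the compounds with values here, this change also removes the hydroxy, as the step from compound 2 to compound 3 did, but puts in a methyl rather than heptyl, so the group stays close in size to the one in compound 1. A lower number than the limit of compound 2 is therefore expected, of a size nearer the step into compound 1 than the large step into compound 3. For compound 4 the expected step is an at least 1.6-fold lower number from compound 2 to compound 4 (0.22 log units; that floor lies within the scatter). In this assay compound 4 is estimated at 60000 nM, with a range from 20000 nM to 150000 nM.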

Compound 4, half-maximal inhibitory concentration: 19000 nM
Compound 4: the middle estimate sits 3.2-fold (0.50 log units) above what was measured, outside the stated range (below it).
By their numbers in this assay, from the lowest: compound 3; then compound 4; then compound 1. At a limit, above all of these: compound 2.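

In this assay, the 1,2-dimethylpropyl group gives an at least 5.2-fold lower number from compound 2 to compound 4 (0.72 log units; beyond the scatter) and so shows that the hydroxy can go without heptyl entering; the earlier compounds had shown a drop on losing the hydroxy only together with that long chain. Within the data shown here, the same group gives a 3.9-fold lower number from compound 1 to compound 4 (0.60 log units; beyond the scatter) and so adds that, at this place on a saturated chain carbon bound to two aromatic carbons, the chain without fluorine also separates from the 2-(fluoromethyl)-1-methylpropyl chain of compound 1, which the earlier compounds could not show. The first of these steps is only a floor, and compound 2 stands at a limit and not at a number: the limit of > 100000 nM in this assay, at which 1 of the 4 values shown sits.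

The compounds shown leave open how the number moves between the short chain and the long one, with compound 4 at 19000 nM and compound 3 at 3100 nM and no butyl or pentyl chain in between to show whether the fall is gradual. They also leave open whether an amine or a carboxylic acid on this chain would sit with the hydroxy of compound 2 or with the plain chain of compound 4.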